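Swapping a propyl chain for a cyanophenyl ring

This account rests on a few compounds, and the source may have more. Where it says the series, first, only, none or still open, it means among the compounds named here.

Three compounds share one core and differ only in the group on a saturated chain carbon bound to an aromatic nitrogen. Compound 1 `NC(=O)Cn1c(=O)n(C2OC(CO)[C@@H](O)[C@H]2O)c2nc(N)nc(O)c21` gives 190 uM in a functional assay (B cells) with Mus musculus as the target; a higher number here means that more compound is needed for the effect, a lower number that less compound is needed. Compound 2 `CN(C)CCCn1c(=O)n(C2OC(CO)[C@@H](O)[C@H]2O)c2nc(N)nc(O)c21` gives 194 uM in the same assay, and compound 3 `CCCCn1c(=O)n(C2OC(CO)[C@@H](O)[C@H]2O)c2nc(N)nc(O)c21` gives 11 uM. Compound 3 stands lowest of the three: a 17-fold lower number from compound 1 to compound 3 (1.24 log units; beyond the scatter), and an 18-fold lower number from compound 2 to compound 3 (1.25 log units; beyond the scatter), while a 1.0-fold higher number from compound 1 to compound 2 (0.01 log units; within the scatter).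

Compound 4 `N#Cc1ccc(Cn2c(=O)n(C3OC(CO)[C@@H](O)[C@H]3O)c3nc(N)nc(O)c32)cc1` is not yet measured. Its difference from compound 3 is 4-cyanophenyl in place of propyl on a saturated chain carbon bound to an aromatic nitrogen. Among the measured compounds shown here, no measured step involves an aromatic ring entering at this place, so none bears directly on this change. The two large steps show that a propyl chain here gives a far lower number than either a carbamoyl or a dimethylamino group, so the group at this position matters a great deal, and moving away from propyl carries a real chance of losing ground. The 4-cyanophenyl group brings one hydrogen-bond acceptor, as the carbamoyl of compound 1 did, but no donor, so it sits between the measured cases. Compound 4 is therefore expected to give a somewhat higher number than compound 3, with a 2.7-fold higher number from compound 3 to compound 4 (0.44 log units; beyond the scatter) as the estimated step, and an estimated value of 30 uM, ranging from 8 uM to 120 uM.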

Compound 4, concentration for half-maximal effect: 15 uM
Compound 4: the middle estimate sits 2.0-fold (0.30 log units) above what was measured; the measured number falls inside the stated range.
By their numbers in this assay, from the lowest: compounds 3 and 4 (each within the scatter of the next); then compounds 1 and 2 (each within the scatter of the next).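

In this assay, 4-cyanophenyl can stand in place of propyl on a saturated chain carbon bound to an aromatic nitrogen without a readable change (a 1.4-fold higher number from compound 3 to compound 4 (0.13 log units; within the scatter)), even though it brings 8 heavy atoms against 3, an aromatic ring and a hydrogen-bond acceptor. Compound 4 also keeps the large distance from the two higher compounds that compound 3 showed (a 13-fold lower number from compound 2 to compound 4 (1.11 log units; beyond the scatter); a 13-fold lower number from compound 1 to compound 4 (1.10 log units; beyond the scatter)), so among these four compounds, the low number is not confined to a plain saturated chain, and the acceptor that compound 4 shares with the carbamoyl of compound 1 does not bring the high number with it. Nothing in the data explains why propyl and 4-cyanophenyl give such similar numbers.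

A plain benzyl group, with the ring but without the nitrile, would show whether the nitrile plays any part in the number of compound 4. A longer chain such as hexyl, or a carboxylic acid at the end of a chain, would show how widely the group at this place can vary before the number climbs again.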